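This account rests on a few compounds, and the source may have more. Where it says the series, first, only, none or still open, it means among the compounds named here.

Compound 1 `CCCC[S+]([O-])c1sc2nc(-c3nccs3)cc(-c3ccc(C(=O)OC)cc3)c2c1N` is one of three compounds whose inhibition was measured in an assay for inhibition of 15-hydroxyprostaglandin dehydrogenase [NAD(+)] (Homo sapiens), read by fluorescence, with a stated time of 15 min, in the presence of a further agent that is not named here; a higher number here means a weaker inhibitor, a lower number a stronger inhibitor. In this assay compound 1 gives 15.1 nM, the lowest of the three numbers. Compound 3 `CCCCS(=O)(=O)c1sc2nc(-c3cccs3)cc(-c3ccccc3)c2c1N` gives 25 nM in this assay, a gap to compound 1 that lies within the scatter, so the two cannot be ranked against each other. Compound 2 `CCCC[S+]([O-])c1nc2ccc(-c3cccs3)nc2s1` gives 1230 nM in this assay, which stands well beyond the scatter from compound 1.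

Compound 4 `CCCC[S+]([O-])c1sc2nc(-c3nccs3)cc(-c3ccc(C(C)(C)O)cc3)c2c1N` has not yet been measured. It differs from compound 1 by 1-hydroxy-1-methylethyl in place of methoxycarbonyl on an aromatic carbon; the group sits on an aromatic carbon of a six-membered aromatic ring of carbon only, para to a large group. Among the compounds with values here, no measured pair shows this exact change, so the size of the step is open. Compound 4 is expected to stay close to compound 1, with an estimated step from compound 1 to compound 4 of a 1.7-fold higher number from compound 1 to compound 4 (0.22 log units; within the scatter), no larger than the scatter. The estimate for compound 4 in this assay is 25 nM, within a range from 6 nM to 100 nM.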

Compound 4, half-maximal inhibitory concentration: 3.6 nM
The estimate for compound 4 lay 6.9-fold (0.84 log units) above the measured number; the whole stated range lies above it.
By their numbers in this assay, from the lowest: compound 4; then compounds 1 and 3 (each within the scatter of the next); then compound 2.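

In this assay, 1-hydroxy-1-methylethyl in place of methoxycarbonyl, on an aromatic carbon para to a large group, gives a 4.2-fold lower number from compound 1 to compound 4 (0.62 log units; beyond the scatter), a step beyond the scatter. Within the data shown here, the earlier compounds offered no pair differing in one place, so this is the first single change that can be read, and it shows that methoxycarbonyl is not required at this position for a low number and that the group held here affects the reading. No measurement shown explains the step.

The change replaces a group with no hydrogen-bond donor by one with a hydrogen-bond donor and also alters the carbon skeleton, so the compounds shown cannot separate these two differences. From the compounds shown here alone, how a hydroxymethyl group, a carboxylic acid or an amine at this position would read also remains open.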